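A few compounds are considered here, and "the series" means these few. Any claim that something is new, unique, unknown or untested is made for them only; others in the source may bear on it.

Measured so far, in a functional assay on U-87MG ATCC cells (Homo sapiens) for cytotoxicity, read by MTT assay, with a stated time of 72 h; on this read-out higher numbers stand for weaker inhibition and lower numbers for stronger inhibition:
- compound 1 `CCN(Cc1ccc(-c2ccnc3ccc(-c4cnc(OC)c(NS(=O)(=O)c5ccc(F)cc5F)c4)cc23)cc1)C1CCCCC1` gives 1450 nM
- compound 2 `COc1ncc(-c2ccc3nccc(-c4ccc(CN5CCCCC5)cc4)c3c2)cc1NS(=O)(=O)c1ccc(F)cc1F` gives 32 nM

Compound 2 stands at the lowest of the two numbers in this assay; its nearest neighbour is compound 1, and the step of a 45-fold lower number from compound 1 to compound 2 (1.66 log units; beyond the scatter) lies beyond the scatter. Compound 3 `COc1ncc(-c2ccc3nccc(-c4ccc(Cn5ccnc5)cc4)c3c2)cc1NS(=O)(=O)c1ccc(F)cc1F` has not been measured. It differs from compound 2 by 1H-imidazol-1-yl in place of piperidin-1-yl on a saturated chain carbon bound to an aromatic carbon. Within the data shown here, the only measured step that bears on this change is the one at the same place, a 45-fold lower number from compound 1 to compound 2 (1.66 log units; beyond the scatter), which shows that swapping the group on that saturated chain carbon can move the number a great deal in this assay. Nothing measured shows what a five-membered aromatic ring does there. The expectation for compound 3 in this assay is therefore uncertain, leaning toward a higher number, a 4.7-fold higher number from compound 2 to compound 3 (0.67 log units; beyond the scatter). Compound 3 is estimated at 150 nM, with a range from 25 nM to 900 nM.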

Compound 3, half-maximal inhibitory concentration: 600 nM
For compound 3 the middle estimate is 4.0-fold (0.60 log units) below the measured one; the measured number falls inside the stated range.
By their numbers in this assay, from the lowest: compound 2; then compound 3; then compound 1.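

In this assay, replacing piperidin-1-yl with 1H-imidazol-1-yl on this saturated chain carbon gives a 19-fold higher number from compound 2 to compound 3 (1.27 log units; beyond the scatter), so the five-membered aromatic ring does not keep the low number of the six-membered non-aromatic ring. Replacing cyclohexyl(ethyl)amino with 1H-imidazol-1-yl gives a much smaller change, a 2.4-fold lower number from compound 1 to compound 3 (0.38 log units; beyond the scatter), which places 1H-imidazol-1-yl between the other two groups and shows that all three can be told apart at this place. Nothing available explains these differences.

The compounds shown leave open whether the low number of compound 2 is special to piperidin-1-yl or extends to other saturated rings, such as pyrrolidin-1-yl or morpholin-4-yl. They also leave open whether another five-membered aromatic ring, such as 1H-pyrazol-1-yl, would behave like 1H-imidazol-1-yl.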